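The compounds below may be only part of what the source reports. "The series", "measured", "known", "first", "only" and "open" are said of these compounds alone.

Measured compounds:
compound 1 `Cc1nc(S(C)(=O)=O)ccc1Oc1ncnc(OC2CCN(C(=O)SC(C)(C)C)CC2)c1F`: 76%
compound 2 `Cc1nc(S(C)(=O)=O)ccc1Oc1ncnc(OC2CCN(C(=O)C3(F)CCC3)CC2)c1F`: 91%

Among the compounds with values here, in a functional assay on isolated protein for inhibition of Glucose-dependent insulinotropic receptor (Rattus norvegicus), read by HTRF and cAMP accumulation (a lower number here means a smaller maximal response, a higher number a larger maximal response), compound 2 gives 91%, the higher of the two values; the single measured step, a number 15 percentage points higher from compound 1 to compound 2 (beyond the scatter), separates it from compound 1. Compound 3 `Cc1nc(S(C)(=O)=O)ccc1Oc1ncnc(OC2CCN(C(=O)C3CCCC3)CC2)c1F` is the next compound, differing from compound 2 by a group of 5 heavy atoms (5 carbon; one five-membered non-aromatic ring of carbon only) in place of a group of 5 heavy atoms (4 carbon, 1 fluorine; one four-membered non-aromatic ring of carbon only), on a carbonyl carbon. That one measured step bears on it only loosely, as it changed a different group at the same carbonyl carbon, and it was modest. A step from compound 2 to compound 3 of about the same small size, in either direction, is therefore expected, a number 6 percentage points lower from compound 2 to compound 3 (within the scatter). Compound 3 is estimated at 85%, within 70% to 100%.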

Compound 3, largest response reached (reported as efficacy), in percent of the reference or control that the assay uses: 83%
Beside the measured number, compound 3's estimate is 2 percentage points above it, and the stated range covers the measured number.
By their numbers in this assay, from the lowest: compounds 1, 3 and 2 (each within the scatter of the next, the first and the last beyond it).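

In this assay, replacing the fluorinated four-membered ring with cyclopentyl on this carbonyl carbon gives a difference that cannot be told from noise (a number 8 percentage points lower from compound 2 to compound 3 (within the scatter)). Cyclopentyl is equally hard to separate from (tert-butyl)sulfanyl (a number 7 percentage points higher from compound 1 to compound 3 (within the scatter)), so compound 3 overlaps both earlier compounds even though they differ clearly from each other. Nothing available explains these numbers. The compounds shown leave open how an amine or a methoxy group on this carbonyl carbon would read in this assay. They also leave open what a fluorine on the cyclopentyl ring would do.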